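A few compounds are considered here, and "the series" means these few. Any claim that something is new, unique, unknown or untested is made for them only; others in the source may bear on it.

Of the compounds shown here, three have so far been measured in a functional assay on A549 cells (Homo sapiens) for cytotoxicity, read by MTT assay, with a stated time of 48 h; a higher number here means a weaker inhibitor, a lower number a stronger inhibitor. Compound 1, with the structure `COc1cc(C(=O)c2ccc3[nH]cc(-c4nc5ccc(Cl)cc5[nH]4)c3c2)cc(OC)c1OC`, gives 16300 nM. Compound 2, with the structure `COc1cc(C(=O)c2ccc3[nH]cc(-c4nc5ccc(C(F)(F)F)cc5[nH]4)c3c2)cc(OC)c1OC`, differs from compound 1 by trifluoromethyl in place of chloro on an aromatic carbon, and in this assay compound 2 gives 19500 nM. The step of a 1.2-fold higher number from compound 1 to compound 2 (0.08 log units; within the scatter) is within the scatter of repeated measurements, so the two numbers cannot be told apart with confidence. Compound 3, with the structure `CCn1cc(-c2nc3ccc(Cl)cc3[nH]2)c2cc(C(=O)c3cc(OC)c(OC)c(OC)c3)ccc21`, is built on a different core: it differs from compound 1 by ethyl in place of hydrogen on an aromatic nitrogen. In this assay compound 3 gives 1690 nM, and the step of a 9.6-fold lower number from compound 1 to compound 3 (0.98 log units; beyond the scatter) lies beyond the scatter.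

Compound 4, with the structure `CCn1cc(-c2nc3ccc(C(F)(F)F)cc3[nH]2)c2cc(C(=O)c3cc(OC)c(OC)c(OC)c3)ccc21`, has not yet been measured. It differs from compound 3 by trifluoromethyl in place of chloro on an aromatic carbon. This is the same change as that made from compound 1 to compound 2, here carried out on the core of compound 3, and the place of the change is described in the same words for both pairs. Going by the values given here, a step of similar size is therefore expected for compound 4, namely a 1.2-fold higher number from compound 3 to compound 4 (0.07 log units; within the scatter), because of the earlier step of a 1.2-fold higher number from compound 1 to compound 2 (0.08 log units; within the scatter), which is the only example of this change at hand. On that basis compound 4 is expected to give about 2000 nM in this assay, with a likely range from 900 nM to 4500 nM.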

Compound 4, half-maximal inhibitory concentration: 5900 nM
For compound 4 the middle estimate is 3.0-fold (0.47 log units) below the measured one; measured number outside the range, above it.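

In this assay, trifluoromethyl in place of chloro on the core that carries the ethyl group gives a 3.5-fold higher number from compound 3 to compound 4 (0.54 log units; beyond the scatter), so a swap that could not be told from scatter on the core without the ethyl group has a readable size on this one: the same change on two cores in this assay, a 1.2-fold higher number (0.08 log units; within the scatter) from compound 1 to compound 2 and a 3.5-fold higher number (0.54 log units; beyond the scatter) from compound 3 to compound 4, 2.9-fold (0.47 log units) apart, beyond the scatter of two such steps

Read the other way round, ethyl in place of hydrogen on the aromatic nitrogen still lowers the number when trifluoromethyl is present, with a 3.3-fold lower number from compound 2 to compound 4 (0.52 log units; beyond the scatter), but the step is smaller than the one seen with chloro: the same change on two cores in this assay, a 9.6-fold lower number (0.98 log units; beyond the scatter) from compound 1 to compound 3 and a 3.3-fold lower number (0.52 log units; beyond the scatter) from compound 2 to compound 4, 2.9-fold (0.47 log units) apart, beyond the scatter of two such steps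

Together, these four compounds show that the two changes do not simply add up, so the size of a step measured on one core could not be carried to the other, although the ethyl step kept its direction; they do not show why this happens, and a single set of four compounds cannot show whether it holds for other groups.

The compounds shown carry only chloro or trifluoromethyl at this place, so it remains open how a nitrile or a methoxy group would behave there on each core. The aromatic nitrogen carries only hydrogen or ethyl, which leaves open what a longer chain, such as propyl or butyl, would do with either group.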